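Adding trifluoromethyl to compound 3: what to expect

The source may report more compounds than this note shows. Statements on the series, on what has been measured and on what is new or still open speak of the compounds shown alone.

Compound 1 `CCC(=O)NCc1cccc(C(=O)Nc2ccc(C)c(Nc3nccc(-c4cccnc4)n3)c2)c1` in an ADME assay on BaF3 cells (Mus musculus) for cytotoxicity, read by CellTiter-Glo and CCK-8 assay, with a stated time of 72 h (on this read-out higher numbers stand for weaker inhibition of growth and lower numbers for stronger inhibition of growth), gives 4750 nM
Compound 2 `C=CC(=O)NCc1cccc(C(=O)Nc2ccc(C)c(Nc3nccc(-c4cccnc4)n3)c2)c1` gives > 10000 nM (a limit of the assay)
Compound 3 `C=CC(=O)Nc1cccc(C(=O)Nc2ccc(C)c(Nc3nccc(-c4cccnc4)n3)c2)c1` gives 2480 nM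

Compound 3 stands level with compound 1 within the scatter, while compound 2 has only a limit. Compound 4 `C=CC(=O)Nc1cc(C(=O)Nc2ccc(C)c(Nc3nccc(-c4cccnc4)n3)c2)cc(C(F)(F)F)c1` differs from compound 3 by trifluoromethyl in place of hydrogen on an aromatic carbon. Going by the values given here, no measured step adds such a group. The nearest steps change another group on this ring, with a 1.9-fold lower number from compound 1 to compound 3 (0.28 log units; within the scatter) and an at least 4.0-fold lower number from compound 2 to compound 3 (0.60 log units; beyond the scatter) as their sizes, and they give no direction for this change. In this assay the expected result is no step beyond the scatter, namely a 1.4-fold lower number from compound 3 to compound 4 (0.14 log units; within the scatter) as an estimate. Compound 4 is estimated at 1800 nM (expected range 500 nM to 6000 nM).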

Compound 4, concentration for 50% growth inhibition: 5460 nM
The estimate for compound 4 lay 3.0-fold (0.48 log units) below the measured number; the measured number falls inside the stated range.
By their numbers in this assay, from the lowest: compounds 3, 1 and 4 (each within the scatter of the next, the first and the last beyond it). At a limit, above all of these: compound 2.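

In this assay the ring carbon meta to the (vinylcarbonyl)amino group proves sensitive to substitution: trifluoromethyl in place of hydrogen gives a 2.2-fold higher number from compound 3 to compound 4 (0.34 log units; beyond the scatter) and so moves the read-out towards weaker inhibition of growth. Going by these compounds alone, the earlier steps changed only another group on this ring, so this is the first direction seen for adding a group at this place. Nothing shown here bears on why this step occurs. As far as these compounds go, whether a chlorine atom or an amine at this place would move the number the same way stays open.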